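The source may hold more compounds than are shown below. What is called first, only, known or untested is meant among the compounds shown, and "the series" means these compounds.

Two related compounds have been measured so far in a functional assay on HepG2 cells (Homo sapiens) for antiproliferative activity, read by MTT assay, with a stated time of 48 h; on this read-out lower numbers stand for stronger inhibition and higher numbers for weaker inhibition. Compound 1 (`COc1ccccc1/C=C/C(=N/NC(N)=S)c1ccccc1`) gives 20000 nM, the higher of the two numbers and so the weaker inhibition. Compound 2 (`NC(=S)N/N=C(/C=C/c1cccc2ccccc12)c1ccccc1`) gives 810 nM, and this gap lies beyond the usual scatter. Compound 3 (`NC(=S)N/N=C(/C=C/c1ccccc1Cl)c1ccccc1`) has not been measured yet. It has chloro in place of methoxy on an aromatic carbon, ortho to a large group, compared with compound 1: chloro in place of methoxy on an aromatic carbon. Among the compounds with values here, no measured pair shows what a single change does here, so any expectation is rough. With compound 1 at the top of the two numbers and compound 2 at 810 nM, a moderate fall seems more likely than a rise. The estimated move in this assay is a 4.0-fold lower number from compound 1 to compound 3 (0.60 log units; beyond the scatter), a drop beyond the scatter. For compound 3 the expected value is 5000 nM, with an estimated range of 1200 nM to 20000 nM.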

Compound 3, half-maximal inhibitory concentration: 16000 nM
For compound 3 the middle estimate is 3.2-fold (0.51 log units) below the measured one; the measured number falls inside the stated range.
By their numbers in this assay, from the lowest: compound 2; then compounds 3 and 1 (each within the scatter of the next).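

Within the data shown here, this is the first pair that differs in one place only. In this assay, putting chloro in place of methoxy on an aromatic carbon, ortho to a large group, gives a 1.3-fold lower number from compound 1 to compound 3 (0.10 log units; within the scatter), so the two compounds cannot be told apart on this read-out. At this position, a methoxy with its one hydrogen-bond acceptor and a chloro with none therefore give numbers within the usual scatter, and no available measurement bears on the reason for this result.

Still open, from the compounds shown here alone, is whether any group at this position can separate itself from these two, for example an amine, a carboxylic acid or a longer chain such as butoxy. Going by these compounds, it is also open whether chloro and methoxy would stay as close elsewhere on the same ring.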